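This account rests on a few compounds, and the source may have more. Where it says the series, first, only, none or still open, it means among the compounds named here.

Compound 2 `CCC(C)(C)Cc1c[nH]c(CCc2ccc(-c3cnccn3)cc2)n1` gives 100 nM in a functional assay on HEK293 cells for agonist activity at Bombesin receptor subtype-3 (Homo sapiens), read by luminescence and calcium flux, with a stated time of 10 min (on this read-out higher numbers stand for an effect only at larger amounts of compound and lower numbers for an effect already at smaller amounts), the top of the two numbers shown, separated from compound 1 `CCC(C)(C)Cc1c[nH]c(CCc2ccc(-n3ccnn3)cc2)n1` at 93 nM only by a 1.1-fold higher number from compound 1 to compound 2 (0.03 log units; within the scatter), which stays within the scatter. Compound 3 `CCC(C)(C)Cc1c[nH]c(CCc2ccc(-c3csnn3)cc2)n1` differs from compound 2 by 1,2,3-thiadiazol-4-yl in place of pyrazin-2-yl on an aromatic carbon. For the measured compounds named here, the sole measured step at this place, a 1.1-fold higher number from compound 1 to compound 2 (0.03 log units; within the scatter), swapped one ring for another and moved nothing beyond the scatter, so little is expected from a further swap here. For compound 3 the expected step is a 1.1-fold higher number from compound 2 to compound 3 (0.04 log units; within the scatter), none beyond the scatter. Compound 3 is therefore estimated at 110 nM, between 45 nM and 270 nM.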

Compound 3, half-maximal effective concentration: 104 nM
Compound 3: the middle estimate sits 1.1-fold (0.02 log units) above what was measured; low and high end bracket the measured number.
By their numbers in this assay, from the lowest: compounds 1, 2 and 3 (each within the scatter of the next).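

In this assay, the five-membered 1,2,3-thiadiazol-4-yl, with sulfur in its ring, replaces pyrazin-2-yl with a 1.0-fold higher number from compound 2 to compound 3 (0.02 log units; within the scatter) and replaces 1H-1,2,3-triazol-1-yl with a 1.1-fold higher number from compound 1 to compound 3 (0.05 log units; within the scatter). Across these three compounds, neither ring size nor the sulfur atom moves the number beyond the scatter, so this place on the aromatic carbon, para to a large group, tolerates all three rings alike. Nothing available bears on the reason for this. Still open, as far as these compounds go, is whether an amine, a carboxylic acid or a longer chain at this place would shift the number.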